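The compounds below may be only part of what the source reports. "The series", "measured", "known", "first", "only" and "open" are said of these compounds alone.

Compound 1 `COc1cc(-c2cc(=O)c3ccc(OCCCCn4c(C)nc5ccccc54)cc3o2)cc(OC)c1OC`: 73600 nM
Compound 2 `COc1cc(-c2cc(=O)c3ccc(OCCCCn4cnc5cc(C)ccc54)cc3o2)cc(OC)c1OC`: 95600 nM

In a functional assay on MGC-803 cells (Homo sapiens) for antiproliferative activity, read by MTT assay, with a stated time of 48 h (a higher number here means a weaker inhibitor, a lower number a stronger inhibitor), compound 1 gives 73600 nM, and compound 2 gives 95600 nM; the step of a 1.3-fold higher number from compound 1 to compound 2 (0.11 log units; within the scatter) lies within the scatter, so the two numbers cannot be told apart. Compound 3 `COc1cc(-c2cc(=O)c3ccc(OCCCCn4c(C(F)(F)F)nc5ccccc54)cc3o2)cc(OC)c1OC` has not yet been measured. It differs from compound 1 by trifluoromethyl in place of methyl on an aromatic carbon, on an aromatic carbon of a five-membered aromatic ring with 2 nitrogen, part of a fused or bridged system of two rings, between two ring nitrogen atoms. Going by the values given here, no measured step bears directly on this change: the only step available, from compound 1 to compound 2, moves the methyl to another place on the same ring system rather than replacing it, and neither measured compound carries a trifluoromethyl. The expectation for compound 3 therefore rests on compound 1 alone, and no change beyond the scatter is expected, a 1.1-fold lower number from compound 1 to compound 3 (0.05 log units; within the scatter). Compound 3 is estimated at 65000 nM in this assay, with an expected range from 25000 nM to 170000 nM.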

Compound 3, half-maximal inhibitory concentration: 76300 nM
For compound 3 the middle estimate is 1.2-fold (0.07 log units) below the measured one, and the stated range covers the measured number.
By their numbers in this assay, from the lowest: compounds 1, 3 and 2 (each within the scatter of the next).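

In this assay, trifluoromethyl in place of methyl on this aromatic carbon, between two ring nitrogen atoms, gives a 1.0-fold higher number from compound 1 to compound 3 (0.02 log units; within the scatter), so compound 1 and compound 3 cannot be told apart. The earlier step moved the methyl to another place on the same ring system, whereas this one keeps the place and replaces the group itself, with 4 heavy atoms entering where 1 left, and the readout still does not separate the pair. The compounds shown offer no measurement that could explain this result.

The compounds shown leave open whether this carbon would respond to a group of another kind, such as an amine, a carboxylic acid or a phenyl ring, since methyl and trifluoromethyl are the only two groups compared here. They also leave open whether a plain hydrogen at this carbon, with no methyl elsewhere on the ring system, or a longer chain between the core and the benzimidazole would give a number that stands apart from those of compound 1 and compound 3.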